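Methoxy to Ethoxy on a Weakly Active Aortic Inhibitor

A few compounds are considered here, and "the series" means these few. Any claim that something is new, unique, unknown or untested is made for them only; others in the source may bear on it.

Of the compounds shown here, two have been tested in a functional assay on aorta (strain Wistar) for inhibition, with Thoracic aorta (Rattus norvegicus) as the target; a higher number here means a weaker inhibitor, a lower number a stronger inhibitor. Compound 1 `CCOc1nc(-c2cc3ccccc3o2)cc(-c2ccccc2)c1C#N` gives 310000 nM in this assay. Compound 2 `COc1ccc(-c2cc(-c3cc4ccccc4o3)nc(OC)c2C#N)c(OC)c1` gives 425000 nM in this assay; on the bare numbers it stands at the top of the pair, but the gap to compound 1 lies within the usual scatter of repeated measurements, so the two cannot be told apart. Both are very weak inhibitors.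

Compound 3 `CCOc1nc(-c2cc3ccccc3o2)cc(-c2ccc(OC)cc2OC)c1C#N` has not yet been measured. It differs from compound 2 in a single place: methyl in place of hydrogen on a saturated chain carbon bound to an oxygen on an aromatic ring. Among the compounds with values here, compound 1 carries the same ethoxy group on the shared core, but with a different aryl substituent, so no measured pair shows this one change on its own.

Within the data shown here, with only two weak compounds in hand and no direct comparison for this change, the expected step is one that stays within the scatter, estimated at a 1.2-fold lower number from compound 2 to compound 3 (0.08 log units; within the scatter). Compound 3 is therefore expected to give about 350000 nM in this assay, with a plausible range from 150000 nM to 800000 nM.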

Compound 3, half-maximal inhibitory concentration: 488000 nM
The estimate for compound 3 lay 1.4-fold (0.14 log units) below the measured number; the measured number falls inside the stated range.
By their numbers in this assay, from the lowest: compounds 1, 2 and 3 (each within the scatter of the next).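

Methyl in place of hydrogen on a saturated chain carbon bound to an oxygen on an aromatic ring, the change from methoxy to ethoxy, can now be read on its own: it gives a 1.1-fold higher number from compound 2 to compound 3 (0.06 log units; within the scatter) in this assay, so this change leaves compound 2 and compound 3 indistinguishable. With the ethoxy group held fixed, 2,4-dimethoxyphenyl in place of phenyl on an aromatic carbon gives a 1.6-fold higher number from compound 1 to compound 3 (0.20 log units; within the scatter), so this larger change in the aryl substituent also produces no difference that can be told from the scatter in this assay. No other measurement is available here to help interpret either result.

Within the data shown here, all three compounds are very weak inhibitors, so these flat steps show only that neither change lifts the series out of that weak range, and they say little about how the same changes would behave on a stronger inhibitor. On these data alone, whether a longer chain such as propyl in place of the ethyl, or an amine or a carboxylic acid on that chain, would shift the number beyond the scatter remains open.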